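Ethoxycarbonyl in place of 3,4-dichlorophenyl on a carbonyl carbon

This account rests on a few compounds, and the source may have more. Where it says the series, first, only, none or still open, it means among the compounds named here.

Measured in a functional assay on HUVEC cells (Homo sapiens) for inhibition; a lower number here means a stronger inhibitor, a higher number a weaker inhibitor:
compound 1 `COc1cc(/C=C/C(=O)c2cccc(NC(=O)c3ccc(Cl)cc3)c2)ccc1O`: 0.76 ug/mL
compound 2 `COc1cc(/C=C/C(=O)c2cccc(NC(=O)c3ccco3)c2)ccc1O`: 0.38 ug/mL
compound 3 `COc1cc(/C=C/C(=O)c2cccc(NC(=O)c3ccc(Cl)c(Cl)c3)c2)ccc1O`: 2.97 ug/mL

Compound 3 stands highest of the three and is the weakest inhibitor among them. Its two gaps lie beyond the scatter: a 3.9-fold higher number from compound 1 to compound 3 (0.59 log units; beyond the scatter) and a 7.8-fold higher number from compound 2 to compound 3 (0.89 log units; beyond the scatter). The unmeasured compound 4 `CCOC(=O)C(=O)Nc1cccc(C(=O)/C=C/c2ccc(O)c(OC)c2)c1` carries ethoxycarbonyl in place of 3,4-dichlorophenyl on a carbonyl carbon. Within the data shown here, no measured compound has a group without a ring at this place, so the evidence is indirect. Read in reverse, the two modest steps above show the number falling whenever 3,4-dichlorophenyl is left behind. The remaining step, a 2.0-fold lower number from compound 1 to compound 2 (0.30 log units; within the scatter), stays within the scatter and does not separate those two groups. A modest move to a lower number in this assay is therefore expected, though its size is uncertain. The expected step is a 3.3-fold lower number from compound 3 to compound 4 (0.52 log units; beyond the scatter). For compound 4 the estimated value is 0.9 ug/mL, with an expected range of 0.3 ug/mL to 2.8 ug/mL.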

Compound 4, half-maximal inhibitory concentration: 13.3 ug/mL
Estimate against measurement, compound 4: 15-fold (1.17 log units) below, outside the stated range (above it).
By their numbers in this assay, from the lowest: compounds 2 and 1 (each within the scatter of the next); then compound 3; then compound 4.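

In this assay compound 4 is the weakest inhibitor of the four, with a 4.5-fold higher number from compound 3 to compound 4 (0.65 log units; beyond the scatter) and an 18-fold higher number from compound 1 to compound 4 (1.24 log units; beyond the scatter) and also a 35-fold higher number from compound 2 to compound 4 (1.54 log units; beyond the scatter). Leaving 3,4-dichlorophenyl behind therefore does not by itself lower the number: among these four compounds, all three groups with a ring on this carbonyl carbon stand lower than ethoxycarbonyl, which has none, and no compound shown goes against this. No measurement shown here bears on the cause of this rise.

On these data alone, whether the rise follows the loss of the ring or the ethoxycarbonyl group itself stays open, and a cyclohexyl ring, a plain ethyl group or a longer alkyl chain at this place would help separate the two readings. As far as these compounds go, a carboxylic acid in place of the ethoxycarbonyl is equally open.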